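Dimethylphenyl Analogue in a Diacylhydrazine Ecdysone Agonist Series

The source may hold more compounds than are shown below. What is called first, only, known or untested is meant among the compounds shown, and "the series" means these compounds.

Three compounds have been measured:
compound 1 `Cc1ccccc1C(=O)NN(C(=O)c1ccccc1Cl)C(C)(C)C` gives 72.4 nM in an assay on cells for agonist activity at ecdysone receptor (Bombyx mori), read by a luciferase reporter, with a stated time of 24 h; on this read-out lower numbers stand for an effect already at smaller amounts and higher numbers for an effect only at larger amounts of compound;
compound 2 `COc1cccc(C(=O)NN(C(=O)c2ccccc2Cl)C(C)(C)C)c1` gives 52.5 nM in this assay;
compound 3 `CC(C)(C)N(NC(=O)c1ccc(Br)cc1)C(=O)c1ccccc1Cl` gives 33.9 nM in this assay.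

Among the measured compounds shown here, compound 3 has the lowest number of the three; only the step of a 2.1-fold lower number from compound 1 to compound 3 (0.33 log units; beyond the scatter) is beyond the scatter, while a 1.5-fold lower number from compound 2 to compound 3 (0.19 log units; within the scatter) and a 1.4-fold lower number from compound 1 to compound 2 (0.14 log units; within the scatter) are within it. Compound 4 `Cc1ccc(C(=O)NN(C(=O)c2ccccc2Cl)C(C)(C)C)c(C)c1` is not yet measured. It differs from compound 3 by 2,4-dimethylphenyl in place of 4-bromophenyl on a carbonyl carbon. For the measured compounds named here, the step of a 2.1-fold lower number from compound 1 to compound 3 (0.33 log units; beyond the scatter) is the one measured change bearing on this: compound 1 already carries a 2-methylphenyl on that carbonyl carbon, and the 2,4-dimethylphenyl of compound 4 adds a second methyl to it. Going by the values given here, no measured step covers that added methyl. Compound 4 is therefore expected to return toward compound 1, a step of a 1.6-fold higher number from compound 3 to compound 4 (0.21 log units; within the scatter) toward a higher number, modest in size. Compound 4 is estimated at 55 nM, in the range 25 nM to 120 nM.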

Compound 4, half-maximal effective concentration: 162 nM
The estimate for compound 4 lay 2.9-fold (0.47 log units) below the measured number; the measured number lies above the stated range.
By their numbers in this assay, from the lowest: compounds 3, 2 and 1 (each within the scatter of the next, the first and the last beyond it); then compound 4.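

In this assay, among the compounds shown here, the added methyl on an aromatic carbon, a change no earlier step covered, is not neutral: the step of a 2.2-fold higher number from compound 1 to compound 4 (0.35 log units; beyond the scatter) comes from that single methyl. On this carbonyl carbon, 2,4-dimethylphenyl now stands highest of the four groups, with a 3.1-fold higher number from compound 2 to compound 4 (0.49 log units; beyond the scatter) and a 4.8-fold higher number from compound 3 to compound 4 (0.68 log units; beyond the scatter) also beyond the scatter. Nothing measured here explains this rise.

Going by these compounds, whether an ethyl group, a longer chain or an amine in place of that added methyl would raise the number as well stays open.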